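Swapping methoxy for fluoro on a shared quinone-like core

The source may hold more compounds than are shown below. What is called first, only, known or untested is meant among the compounds shown, and "the series" means these compounds.

Of the compounds shown here, three that share one core have been tested in a functional assay on BXPC-3 cells (Homo sapiens) for cytotoxicity, read by MTT assay, with a stated time of 72 h; a higher number here means a weaker inhibitor, a lower number a stronger inhibitor. Compound 1 `COc1cc(NC2=CC(=O)c3ncncc3C2=O)cc(OC)c1OC` gives 1600 nM. Compound 2 `COc1ccc(-c2ccc(NC3=CC(=O)c4ncncc4C3=O)cc2)cc1` gives 3500 nM. Compound 3 `CC(=O)c1cccc(NC2=CC(=O)c3ncncc3C2=O)c1` gives 5200 nM. Among these three numbers compound 2 stands second highest. Its closest neighbour is compound 3, whose number lies within the usual scatter of that of compound 2, so no order can be read between the two. Compound 1 lies further away, with a number low enough to count as a real difference from compound 2.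

Compound 4 `O=C1C(Nc2ccc(-c3ccc(F)cc3)cc2)=CC(=O)c2ncncc21` has not yet been measured in this assay. It differs from compound 2 in one place: fluoro in place of methoxy on an aromatic carbon. Among the measured compounds shown here, no measured pair with this kind of change is available, so the size of the step cannot be read from the other compounds.

Compound 4 is therefore expected to stay close to compound 2 in this assay, and the step of no change at the digits printed from compound 2 to compound 4 (within the scatter) is estimated to be small, with no clear direction beyond the usual scatter. The estimate for compound 4 is 3500 nM, expected to fall between 1500 nM and 8000 nM.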

Compound 4, half-maximal inhibitory concentration: 4400 nM
Compound 4: middle estimate off by 1.3-fold (0.10 log units), on the low side, and the stated range covers the measured number.
By their numbers in this assay, from the lowest: compound 1; then compounds 2, 4 and 3 (each within the scatter of the next).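

Among the compounds shown here, this is the first measured step at this position: in this assay, the change from 4-methoxyphenyl to 4-fluorophenyl gives a 1.3-fold higher number from compound 2 to compound 4 (0.10 log units; within the scatter) and so allows no order to be read between the two compounds. The group that leaves has 2 heavy atoms and 1 hydrogen-bond acceptor, and the one that enters has 1 heavy atom and 0 hydrogen-bond acceptors, yet on this aromatic carbon, para to a large group, the read-out does not separate them. No data on hand speak to why the two groups read alike here.

Going by these compounds, this rests on a single pair, so it remains open whether other groups at this position, such as an ethoxy group, an amine or a carboxylic acid, would also stay within the scatter of compound 2. On these data alone, it is also open whether the same change would behave alike on a different part of the molecule, since compound 1 and compound 3 offer no one-place comparison with compound 2 or compound 4.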